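The compounds below may be only part of what the source reports. "The series", "measured", "known", "first", "only" and "open" are said of these compounds alone.

Among the compounds with values here, in an ADME assay on L6 cells (Rattus norvegicus) for cytotoxicity (on this read-out lower numbers stand for stronger inhibition and higher numbers for weaker inhibition), compound 1 `OC[C@H]1O[C@@H](n2cnc3c(NC4CCCC4)nc(NC4CCCC4)nc32)[C@H](O)[C@@H]1O` gives 97300 nM as the only number available, so it cannot yet be ranked against anything. Compound 2 `OC[C@H]1O[C@@H](n2cnc3c(NCCC(c4ccccc4)c4ccccc4)nc(NC4CCCC4)nc32)[C@H](O)[C@@H]1O` gives "not determined" (no result reported) and so offers no comparison. Compound 3 `COc1nc(NC2CCCC2)c2ncn([C@@H]3O[C@H](CO)[C@@H](O)[C@H]3O)c2n1` shares the core of compound 1 but has methoxy in place of cyclopentylamino on an aromatic carbon between two ring nitrogen atoms. Within the data shown here, with no measured step to draw on, only a modest change is expected in this assay and, if anything, towards weaker inhibition. The estimated step of a 1.2-fold higher number from compound 1 to compound 3 (0.09 log units; within the scatter) is small. For compound 3 the estimate is 120000 nM with a range from 40000 nM to 300000 nM expected.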

Compound 3, half-maximal inhibitory concentration: 51600 nM
Compound 3: the middle estimate sits 2.3-fold (0.37 log units) above what was measured; measured number inside the range.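

In this assay, putting methoxy in place of cyclopentylamino on the aromatic carbon between two ring nitrogen atoms gives a 1.9-fold lower number from compound 1 to compound 3 (0.28 log units; within the scatter). At this position, then, the two compounds cannot be told apart, even though the ring and the hydrogen-bond donor of cyclopentylamino are gone. No other measurement here offers an explanation for this result. From the compounds shown here alone, it remains open whether a longer chain such as butoxy, a simple amine or a carboxylic acid at this carbon would also stay within the scatter.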